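The source may hold more compounds than are shown below. What is called first, only, known or untested is meant among the compounds shown, and "the series" means these compounds.

The series shares the core of compound 1 `COc1cc2c(cc1OC)C(CC(=O)O)CC2`, which in a functional assay on the whole organism (strain Wistar) for inhibition, with Rattus norvegicus as the target, read by paw edema, with a stated time of 24 h, at a dose of 100 mg/kg (a lower number here means less inhibition, a higher number more inhibition at the dose given (going by the name of the read-out)), gives 26.7%. Among the measured compounds shown here, compound 2 `COc1cc2c(cc1OC)C(CC(=O)Nc1cccc(Cl)c1)CC2` carries (3-chlorophenyl)amino in place of hydroxy on the carbonyl carbon, and in this assay compound 2 gives 63.3%; the step of a number 36.6 percentage points higher from compound 1 to compound 2 (beyond the scatter) is the only measured step in the set. Compound 2 thus stands highest of the two numbers shown, with compound 1 the nearer and lower. Compound 3 `COc1cc2c(cc1OC)C(CC(=O)Nc1ccc(Cl)cc1)CC2` comes next: 4-chlorophenyl in place of 3-chlorophenyl on an amide-type nitrogen. For the measured compounds named here, no measured step exchanges 3-chlorophenyl for 4-chlorophenyl, so the one step available, from hydroxy to (3-chlorophenyl)amino, does not bear directly on this change; it shows only that the (3-chlorophenyl)amino group carries the gain. Going by the values given here, with no step of this kind to lean on, a change within the scatter in this assay is expected, a number 3.3 percentage points lower from compound 2 to compound 3 (within the scatter). Compound 3 is therefore estimated at 60%, in the range 40% to 78%.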

Compound 3, a percentage reported as inhibition, in the whole organism at one dose (the size of the read-out at that dose, not a potency): 70%
Compound 3: the middle estimate sits 10 percentage points below what was measured, within the range that was stated.
By their numbers in this assay, from the lowest: compound 1; then compounds 2 and 3 (each within the scatter of the next).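

In this assay, 4-chlorophenyl in place of 3-chlorophenyl on the amide-type nitrogen amounts to a number 6.7 percentage points higher from compound 2 to compound 3 (within the scatter), so this exchange of two groups with the same atoms does not separate the two amides. The rise over the acid is not tied to 3-chlorophenyl: (4-chlorophenyl)amino in place of hydroxy on the carbonyl carbon also gives a clear step, a number 43.3 percentage points higher from compound 1 to compound 3 (beyond the scatter). Nothing available on the compounds accounts for either step.

Whether the chlorine is needed at all stays open, since the compounds shown include neither plain phenyl nor a cyclohexyl group on the amide-type nitrogen. Also open, from the compounds shown here alone, is what a methyl group in place of the amide hydrogen would do to the read-out.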